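The source may hold more compounds than are shown below. What is called first, only, known or untested is meant among the compounds shown, and "the series" means these compounds.

In an ADME assay on HEK293 cells (Homo sapiens) for cytotoxicity, read by CellTiter-Glo and resazurin assay, with a stated time of 72 h (on this read-out higher numbers stand for an effect only at larger amounts of compound and lower numbers for an effect already at smaller amounts), three compounds built on one shared core have been measured, and every one of them returns only a limit of the assay rather than a number. Compound 1 `CC(C)N(Cc1cccc(OCCCCCC(=O)O)c1)C(=O)c1ccc(-c2cccc(Cl)c2)cc1` gives > 21900 nM in this assay, which is a limit. Compound 2 `CC(C)N(Cc1cccc(OCCCCCC(=O)O)c1)C(=O)c1ccc(-c2cccc(S(C)(=O)=O)c2)cc1` gives > 26000 nM in this assay, again a limit. Compound 3 `CCOC(=O)CCCCCOc1cccc(CN(C(=O)c2ccc(-c3ccc4ccccc4c3)cc2)C(C)C)c1` gives > 26000 nM in this assay, also a limit. Within the data shown here, the single recorded step, a step that the two limits leave unreadable from compound 1 to compound 2, cannot be read because the limit of > 21900 nM in this assay, at which 1 of the 3 values shown sits, and the limit of > 26000 nM in this assay, at which 2 of the 3 values shown sit, both cap the values. Compound 3 therefore stands at the limit that two of the three values share, with nothing in the set lying below any limit. Compound 4 `CCOC(=O)CCCCCOc1cccc(CN(C(=O)c2ccc(-c3cc(OC)ccc3F)cc2)C(C)C)c1` differs from compound 3 by one change, (2-fluoro-5-methoxyphenyl in place of naphthalen-2-yl on an aromatic carbon). Among the measured compounds shown here, no measured step bears on this change, and the only step recorded gives no size at all. Compound 4 is accordingly expected to sit at the limit as well, estimated at 26000 nM with a range from 13000 nM to 52000 nM. The expected step of a number no higher from compound 3 to compound 4 (the limit leaves the size open) is thus none beyond the scatter.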

Compound 4, half-maximal effective concentration: > 26000 nM
Compound 4 was reported as a limit (the forecaster's own chance of this, stated with the estimate: 85%); the middle value lies on the limit itself.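

Compound 3 and compound 4 each return only a limit in this assay, so no step can be read between them. The compounds shown leave open where any of them would reach a half-maximal effect, and whether naphthalen-2-yl and 2-fluoro-5-methoxyphenyl differ there at all.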